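The source may hold more compounds than are shown below. What is called first, only, known or untested is meant among the compounds shown, and "the series" means these compounds.

Measured so far in an ADME assay on the whole organism (Mus musculus, strain CD-1) for pharmacokinetics, at a dose of 10 mg/kg by the oral route; on this read-out lower numbers stand for lower exposure and higher numbers for higher exposure at the dose given:
- Compound 1 `CCOc1cc([C@](O)(CCN(C)C)[C@@H](c2cc3cc(Br)ccc3nc2OC)c2cccc(OC)c2F)cc(OC)n1` gives 4000 ng.h/mL.
- Compound 2 `COc1cc([C@](O)(CCN(C)C)[C@@H](c2cc3cc(Br)ccc3nc2OC)c2cccc(OC)c2F)cc(OC(C)C)n1` gives 9000 ng.h/mL.
- Compound 3 `COc1cc([C@](O)(CCN(C)C)[C@@H](c2cc3cc(Br)ccc3nc2OC)c2cccc(OC)c2F)cc(OC(F)F)n1` gives 14400 ng.h/mL.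

Compound 3 stands highest of the three numbers in this assay. Its nearest neighbour is compound 2, a gap within the scatter; its furthest is compound 1, a gap beyond the scatter. Compound 4 `COc1cc([C@](O)(CCN(C)C)[C@@H](c2cc3cc(Br)ccc3nc2OC)c2cccc(OC)c2F)cc(SC)n1` differs from compound 3 in one place: methylsulfanyl in place of difluoromethoxy on an aromatic carbon.

Going by the values given here, no measured step swaps in a methylsulfanyl group, so no step bears on it directly. The three measured steps change the group at the same ring position: a 2.3-fold higher number from compound 1 to compound 2 (0.35 log units; beyond the scatter), a 3.6-fold higher number from compound 1 to compound 3 (0.56 log units; beyond the scatter) and a 1.6-fold higher number from compound 2 to compound 3 (0.20 log units; within the scatter). All three are modest or within the scatter, which suggests that changes at this position move the read-out in this assay only modestly. A modest step is therefore expected here, most likely downward, since compound 3 already sits at the top of the measured range, but the direction is uncertain.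

The estimate for compound 4 is 8000 ng.h/mL, with a range from 3000 ng.h/mL to 20000 ng.h/mL, which means an expected step of a 1.8-fold lower number from compound 3 to compound 4 (0.26 log units; within the scatter).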

Compound 4, area under the concentration-time curve: 4600 ng.h/mL
Compound 4: the middle estimate sits 1.7-fold (0.24 log units) above what was measured; the range from low to high includes it.
By their numbers in this assay, from the lowest: compounds 1, 4, 2 and 3 (each within the scatter of the next, the first and the last beyond it).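

In this assay, swapping difluoromethoxy for methylsulfanyl costs exposure by more than the scatter (a 3.1-fold lower number from compound 3 to compound 4 (0.50 log units; beyond the scatter)), so a change at this position can undo the best value seen so far. Against the two plain ether groups, the same sulfur-linked group cannot be told apart from isopropoxy (a 2.0-fold lower number from compound 2 to compound 4 (0.29 log units; within the scatter)) or from ethoxy (a 1.2-fold higher number from compound 1 to compound 4 (0.06 log units; within the scatter)), which leaves difluoromethoxy as the only group here that stands clear of methylsulfanyl. Nothing available explains why these groups differ in exposure.

Going by these compounds, it remains open whether the higher exposure extends to other fluorine-bearing groups, such as trifluoromethoxy, or belongs to difluoromethoxy alone. On these data alone, it is also open where an amine or a longer chain such as butoxy would fall at this position.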